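This account rests on a few compounds, and the source may have more. Where it says the series, first, only, none or still open, it means among the compounds named here.

Within the data shown here, compound 3 `Cc1cc(Cc2cccnc2)c(=O)n(CC(=O)Nc2ccc(Br)cc2)n1` is one of three compounds measured in an assay on HL-60 cells for agonist activity at N-formyl peptide receptor 3 (Homo sapiens), read by calcium flux (on this read-out lower numbers stand for an effect already at smaller amounts and higher numbers for an effect only at larger amounts of compound), and all three sit at the same limit. Compound 3 gives > 50000 nM, which is a limit of this assay and not a number. Compound 1 `Cc1cc(Cc2cccc(Br)c2)c(=O)n(CC(=O)Nc2ccc(Br)cc2)n1` likewise gives > 50000 nM, a limit. Compound 2 `Cc1cc(Cc2ccoc2)c(=O)n(CC(=O)Nc2ccc(Br)cc2)n1` gives > 50000 nM, again a limit. With every value at the limit, the three steps among these compounds cannot be sized: a step that the two limits leave unreadable from compound 1 to compound 2, a step that the two limits leave unreadable from compound 1 to compound 3 and a step that the two limits leave unreadable from compound 2 to compound 3. Among the measured compounds shown here, the only evidence the three values offer is the limit of > 50000 nM in this assay, at which 3 of the 3 values shown sit.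

Compound 4 `COc1ccc(Nc2cc(C)nn(CC(=O)Nc3ccc(Br)cc3)c2=O)cc1` differs from compound 3 in one place: (4-methoxyphenyl)amino in place of (pyridin-3-yl)methyl on an aromatic carbon. For the measured compounds named here, none of the measured steps bears directly on this change. Going by the values given here, the three measured steps exchange one ring for another on the saturated chain carbon, whereas here the whole arm is replaced and the point of attachment on the core changes; and as none of the measured steps has a readable size, they give no direction or magnitude that could be carried over. The expectation for compound 4 therefore rests on the shared starting point alone, and the step from compound 3 to compound 4 is expected to be an at least 1.2-fold lower number from compound 3 to compound 4 (0.09 log units; that floor lies within the scatter). In this assay compound 4 is estimated at 40000 nM, with a range from 5000 nM to 100000 nM, and it is expected that the assay may well report only a limit again.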

Compound 4, half-maximal effective concentration: > 50000 nM
Compound 4 was reported as a limit; the forecaster's own chance of this, stated with the estimate: 65%; middle value at least 1.2-fold (0.09 log units) away from the limit.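

In this assay compound 4 gives > 50000 nM, again a limit and not a number. Its steps from compound 1, compound 2 and compound 3 therefore cannot be read, and the evidence stands as: the limit of > 50000 nM in this assay, at which 4 of the 4 values shown sit. The compounds shown leave open whether any of these groups on the shared core gives a measurable effect in this assay.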